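The source may report more compounds than this note shows. Statements on the series, on what has been measured and on what is new or still open speak of the compounds shown alone.

Compound 1 `Cc1ccc2c(NCc3ccc(NC(=O)C4CCN(Cc5ccccc5)CC4)cc3)nc(N3CCN[C@@H](C)C3)nc2c1` and compound 2 `Cc1ccc2c(NCc3ccc(NC(=O)C4CCN(Cc5ccccc5)CC4)cc3)nc(N3CCCC3)nc2c1` share one core and differ only at the aromatic carbon that carries a small amine ring. In a functional assay on SV5A8 cells (Homo sapiens) for cytotoxicity (a higher number here means a weaker inhibitor, a lower number a stronger inhibitor), compound 1 reaches only a limit of the assay, > 8860 nM. Compound 2 likewise reaches only a limit in this assay, > 7790 nM. Compound 2 therefore stands at the limit of > 7790 nM in this assay, at which 1 of the 2 values shown sits, while compound 1 sits at the limit of > 8860 nM in this assay, at which 1 of the 2 values shown sits. Because both values are limits, the step that the two limits leave unreadable from compound 1 to compound 2 cannot be read in size or direction.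

Compound 3 `CCNc1nc(NCc2ccc(NC(=O)C3CCN(Cc4ccccc4)CC3)cc2)c2ccc(C)cc2n1` is the next compound in this line. Its change from compound 2 is ethylamino in place of pyrrolidin-1-yl on an aromatic carbon. Among the measured compounds shown here, no measured step speaks directly to this change, since the only step known, the one from compound 1 to compound 2, is unreadable. Both measured compounds stop at a limit, so compound 3 is expected to behave much the same, and the step that the limit leaves unreadable from compound 2 to compound 3 is estimated to stay within the usual scatter. Compound 3 is therefore expected to give about 9000 nM in this assay, with a range from 3000 nM to 30000 nM.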

Compound 3, half-maximal inhibitory concentration: > 2140 nM
Compound 3 ended at the assay's limit; the forecaster's own chance of this, stated with the estimate: 70%; the middle value is on the limit's open side.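

In this assay compound 3 reaches only a limit, > 2140 nM. Compound 1, compound 2 and compound 3 all stop at limits, so the steps among them cannot be read in size or direction. The compounds shown leave open what actual value any of them has in this assay, and whether swapping these groups changes it at all.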